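Working notes: compound 2 and the unmeasured compound 4

The compounds below may be only part of what the source reports. "The series", "measured", "known", "first", "only" and "open" are said of these compounds alone.

The set comprises compound 1 `CNC(=O)NC[C@H]1O[C@@H](n2cnc3c(NC(=O)Nc4ccccc4)ncnc32)[C@H](O[Si](c2ccccc2)(c2ccccc2)C(C)(C)C)[C@@H]1O[Si](c1ccccc1)(c1ccccc1)C(C)(C)C`, compound 2 `CNC(=O)NC[C@H]1O[C@@H](n2cnc3c(NC(=O)Nc4ccccc4)ncnc32)[C@H](OC(=O)c2ccccc2)[C@@H]1OC(=O)c1ccccc1` and compound 3 `CNC(=O)NC[C@H]1O[C@@H](n2cnc3c(N)ncnc32)[C@H](OC(C)=O)[C@@H]1OC(C)=O`, all tested in a functional assay on CCRF-CEM cells (Homo sapiens) for antiproliferative activity, with a stated time of 72 h; a lower number here means a stronger inhibitor, a higher number a weaker inhibitor. In this assay compound 1 reports only a limit of the assay, >= 200 ug/mL. In this assay compound 2 likewise reports only a limit, > 200 ug/mL. In this assay compound 3 also gives a limit, > 200 ug/mL. None of the three values is a number: compound 2 and compound 3 sit at the limit of > 200 ug/mL in this assay, at which 2 of the 3 values shown sit, compound 1 at the limit of >= 200 ug/mL in this assay, at which 1 of the 3 values shown sits, and nothing separates any of them beyond the scatter.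

Compound 4 `CNC(=O)NC[C@H]1O[C@@H](n2cnc3c(N)ncnc32)[C@H](OC(=O)c2ccccc2)[C@@H]1OC(=O)c1ccccc1` is still to be measured in this assay. Against compound 2 it shows (hydrogen in place of phenylcarbamoyl on a nitrogen on an aromatic ring). Compound 3 carries hydrogen at that same nitrogen and stays at a limit in this assay. On that basis the step from compound 2 to compound 4 is expected to be a number no higher from compound 2 to compound 4 (the limit leaves the size open), no change beyond the scatter, with another limit the likely outcome. Compound 4 is therefore estimated at 200 ug/mL, within 100 ug/mL to 400 ug/mL.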

Compound 4, half-maximal inhibitory concentration: 19 ug/mL
Compound 4: middle estimate off by 11-fold (1.02 log units), on the high side, and the stated range ends above it.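

In this assay the phenylcarbamoyl group on this nitrogen turns out to matter, since hydrogen in its place gives an at least 10-fold lower number from compound 2 to compound 4 (1.02 log units; beyond the scatter) and compound 4 holds the only actual number among the compounds shown. Compound 3 also carries hydrogen on that nitrogen and gives > 200 ug/mL as a limit of the assay and not a number. Hydrogen at this position is therefore not enough on its own, and the drop is established only for the pair of compound 2 and compound 4, which share their benzoate esters.

Going by these compounds, whether a methyl or an acetyl group on that nitrogen would keep the activity of compound 4, and whether free hydroxyl groups could replace the benzoate esters, stays open. Nothing shown here bears on the reason for the size of this step.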